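This account rests on a few compounds, and the source may have more. Where it says the series, first, only, none or still open, it means among the compounds named here.

The account concerns a functional assay (blood) for inhibition, with Homo sapiens as the target; a lower number here means a stronger inhibitor, a higher number a weaker inhibitor. Compound 1 `CO/N=C(\C)c1ccc(Sc2cc(F)cc(C3CCOCC3)c2)cc1` gives 110 nM in this assay, compound 2 `COC(=O)C(C)(C)CO/N=C(\C)c1ccc(Sc2cc(F)cc(C3CCOCC3)c2)cc1` gives 420 nM, and compound 3 `CO[C@]1(c2cnc(S(=O)(=O)c3ccc(/C(C)=N/OCC#N)cc3)s2)CCO[C@@H](C)C1` gives 140 nM. Among these three numbers compound 2 stands highest: compound 3 sits nearest to it and compound 1 furthest from it, both at lower numbers and both beyond the scatter.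

Compound 4 `CCOC(=O)CO/N=C(\C)c1ccc(Sc2cc(F)cc(C3CCOCC3)c2)cc1` has not yet been measured in this assay. It differs from compound 2 as follows: ethoxycarbonyl in place of 1-(methoxycarbonyl)-1-methylethyl on a saturated chain carbon bound to an oxygen on an unsaturated carbon. Going by the values given here, the only measured step that bears on this place is a 3.8-fold higher number from compound 1 to compound 2 (0.58 log units; beyond the scatter), in which 1-(methoxycarbonyl)-1-methylethyl arrived where compound 1 carried hydrogen. Compound 4 keeps a substituent on that saturated chain carbon, but the ethoxycarbonyl that enters is not the group whose arrival cost compound 2 its potency, so a partial return toward compound 1 is expected, of modest size and uncertain. Compound 4 is therefore expected to give about 250 nM, within 110 nM to 600 nM. The estimate corresponds to a 1.7-fold lower number from compound 2 to compound 4 (0.23 log units; within the scatter), an expected improvement.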

Compound 4, half-maximal inhibitory concentration: 610 nM
The estimate for compound 4 lay 2.4-fold (0.39 log units) below the measured number; measured number outside the range, above it.
By their numbers in this assay, from the lowest: compounds 1 and 3 (each within the scatter of the next); then compounds 2 and 4 (each within the scatter of the next).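

In this assay the exchange of 1-(methoxycarbonyl)-1-methylethyl for ethoxycarbonyl gives a 1.5-fold higher number from compound 2 to compound 4 (0.16 log units; within the scatter) and so does not separate the two ester-bearing groups at this place. Against the hydrogen of compound 1, the step with ethoxycarbonyl reads a 5.5-fold higher number from compound 1 to compound 4 (0.74 log units; beyond the scatter) and stands in the same direction as a 3.8-fold higher number from compound 1 to compound 2 (0.58 log units; beyond the scatter), so the loss no longer rests on a single group but appears with both of them. Dropping from 7 heavy atoms to 5 therefore brings no visible return toward compound 1, and no measurement at hand accounts for this result.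

Going by these compounds, whether the ester itself goes with the loss stays open. A carboxylic acid, an amide or a plain ethyl group at this place could fall with compound 2 and compound 4 or with compound 1.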